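Swapping nitrile for trifluoromethyl on an aromatic ring

The source may hold more compounds than are shown below. What is called first, only, known or untested is meant among the compounds shown, and "the series" means these compounds.

Measured so far:
compound 1, `Nc1nc(-c2ccc(C(F)F)o2)nc2sc(CN3CCC(F)CC3)cc12`: 1670 nM in an assay on CHO-K1 cells for antagonist activity at adenosine receptor A1 (Homo sapiens), read by a beta-galactosidase reporter, with stated times of 15 min and 6 h; a lower number here means a stronger inhibitor, a higher number a weaker inhibitor
compound 2, `N#Cc1ccccc1-c1nc(N)c2cc(CN3CCC(F)CC3)sc2n1`: 5050 nM in this assay
compound 3, `N#Cc1ccc(-c2nc(N)c3cc(CN4CCC(F)CC4)sc3n2)cc1`: 8430 nM in this assay

Compound 2 holds the second highest number of the three. Its nearest neighbour is compound 3, reached by a 1.7-fold higher number from compound 2 to compound 3 (0.22 log units; within the scatter), a step inside the scatter, so the two cannot be ranked. Its furthest neighbour is compound 1, from which it is separated by a 3.0-fold higher number from compound 1 to compound 2 (0.48 log units; beyond the scatter).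

Compound 4, `Nc1nc(-c2ccccc2C(F)(F)F)nc2sc(CN3CCC(F)CC3)cc12`, is built from compound 2 by one change: trifluoromethyl in place of cyano on an aromatic carbon. For the measured compounds named here, no measured step makes this exact exchange. The steps of a 3.0-fold higher number from compound 1 to compound 2 (0.48 log units; beyond the scatter) and a 5.0-fold higher number from compound 1 to compound 3 (0.70 log units; beyond the scatter) replace the whole furan-based group by a cyanophenyl group, and a 1.7-fold higher number from compound 2 to compound 3 (0.22 log units; within the scatter) merely moves the cyano group; all were modest or within the scatter. With nothing closer to lean on, the step from compound 2 to compound 4 is expected to be small, a 1.1-fold lower number from compound 2 to compound 4 (0.05 log units; within the scatter), probably not beyond the scatter. Compound 4 is therefore estimated at 4500 nM in this assay, with a range from 1500 nM to 14000 nM.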

Compound 4, inhibition constant: > 10000 nM
Compound 4 ended at the assay's limit; the forecaster's own chance of this, stated with the estimate: 10%; middle value at least 2.2-fold (0.34 log units) away from the limit.
By their numbers in this assay, from the lowest: compound 1; then compounds 2 and 3 (each within the scatter of the next). At a limit, above all of these: compound 4.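

In this assay compound 4 gives > 10000 nM, which is a limit of the assay and not a measured number: the limit of > 10000 nM in this assay, at which 1 of the 4 values shown sits.

Among the compounds shown, this is the only direct exchange of cyano for trifluoromethyl on the aromatic carbon ortho to a large group, and it gives an at least 1.9-fold higher number from compound 2 to compound 4 (0.29 log units; that floor lies within the scatter). Trifluoromethyl thus brings no lower number at this position, but only a floor is known and that floor lies within the scatter, so the true size of the change cannot be read.

On these data alone, how far beyond the limit compound 4 really lies stays open. Also open, as far as these compounds go, are what an amine, a methoxy group or a carboxylic acid would do on this same carbon, and whether trifluoromethyl in place of the cyano group of compound 3 would give a similar result.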